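A few compounds are considered here, and "the series" means these few. Any claim that something is new, unique, unknown or untested is made for them only; others in the source may bear on it.

Compound 2 `Cn1cnc2c(-c3ccco3)ncnc21` is one of two compounds assessed in a functional assay on K562 cells (Homo sapiens), read by thymidine incorporation; on this read-out higher numbers stand for weaker inhibition and lower numbers for stronger inhibition. In this assay compound 2 gives < 10 ug/mL, which is a limit of the assay rather than a number. Compound 1 `c1csc(-c2[nH]cnc3ncnc2-3)c1` likewise gives < 10 ug/mL, again a limit. Among the measured compounds shown here, both values are described by the limit of < 10 ug/mL in this assay, at which 2 of the 2 values shown sit, so no measured step between them can be stated. Compound 3 `C=CCn1cnc2c(-c3ccco3)ncnc21` differs from compound 2 by vinyl in place of hydrogen on a saturated chain carbon bound to an aromatic nitrogen. For the measured compounds named here, with no comparable measured step available, the step that the limit leaves unreadable from compound 2 to compound 3 is expected to stay within the usual scatter. Compound 3 is therefore estimated to give about 3 ug/mL, within a range of 0.3 ug/mL to 10 ug/mL.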

Compound 3, half-maximal inhibitory concentration: 11 ug/mL
For compound 3 the middle estimate is 3.7-fold (0.56 log units) below the measured one; the measured number lies above the stated range.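

In this assay compound 3 gives 11 ug/mL, the first number rather than a limit for a group at this place, on a saturated chain carbon bound to an aromatic nitrogen. The change from methyl to allyl reads as an at least 1.1-fold higher number from compound 2 to compound 3 (0.04 log units; that floor lies within the scatter). That step is only a floor, because compound 2 stands at a limit: the limit of < 10 ug/mL in this assay, at which 2 of the 3 values shown sit.

Going by these compounds, the true size of the step stays open, so it cannot be said to go beyond the scatter. On these data alone, how a longer chain, an amine or a carboxylic acid at this place would read also remains open.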